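A few compounds are considered here, and "the series" means these few. Any claim that something is new, unique, unknown or untested is made for them only; others in the source may bear on it.

Compounds measured so far:
compound 1 `COc1cccc(/C=C/C(=O)c2ccc(OC)c3c2OC(C)(C)C=C3)c1` — in a functional assay on HepG2 cells (Homo sapiens) for antiproliferative activity, read by MTT assay, with a stated time of 24 h (a higher number here means a weaker inhibitor, a lower number a stronger inhibitor), compound 1 gives > 10000 nM
compound 2 `COc1ccc(C(=O)/C=C/c2ccc3ccccc3n2)c2c1C=CC(C)(C)O2` — compound 2 gives 4280 nM
compound 3 `COc1ccc(C(=O)/C=C/c2cccc3ccccc23)c2c1C=CC(C)(C)O2` — compound 3 gives > 10000 nM

All three share the core of compound 1 and differ only in the group on a double-bonded chain carbon bound to a double-bonded chain carbon. Compound 1 reaches only a limit of this assay, > 10000 nM, so no number is known for it. Compound 3 likewise returns only a limit, > 10000 nM. Compound 2 alone yields a number, 4280 nM. The picture is therefore dominated by the limit of > 10000 nM in this assay, at which 2 of the 3 values shown sit, and compound 1 sits at that limit rather than at a measured point.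

Compound 4 `COc1ccc(C(=O)/C=C/c2ccc(Cl)c(Cl)c2)c2c1C=CC(C)(C)O2` is the next compound. It differs from compound 1 by 3,4-dichlorophenyl in place of 3-methoxyphenyl on a double-bonded chain carbon bound to a double-bonded chain carbon. Going by the values given here, no measured pair in this set shows the effect of that change, so the expectation for this assay rests on compound 1 sitting at the limit and compound 2 showing that a number within reach is possible. The step of an at least 1.2-fold lower number from compound 1 to compound 4 (0.09 log units; that floor lies within the scatter) is expected to be small, at most modest toward stronger inhibition, and the result may again be a limit. Compound 4 is thus estimated at 8000 nM, with a range from 2500 nM to 25000 nM.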

Compound 4, half-maximal inhibitory concentration: > 10000 nM
Compound 4: a limit, no number (the forecaster's own chance of this, stated with the estimate: 55%); at least 1.2-fold (0.09 log units) between middle value and limit.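

Compound 1 and compound 4 both return only a limit in this assay, so no step can be read between them. The compounds shown leave open how 3,4-dichlorophenyl and 3-methoxyphenyl compare on the shared core, and the set stays dominated by a single value: the limit of > 10000 nM in this assay, at which 3 of the 4 values shown sit.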